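The compounds below may be only part of what the source reports. "The series", "measured", "known", "first", "only" and "open" are said of these compounds alone.

Measured in a functional assay on NCI-H460 cells (Homo sapiens) for inhibition, read by MTT assay, with a stated time of 24 h, tested at 1 ug/mL; a lower number here means less inhibition of growth, a higher number more inhibition of growth at the concentration tested:

- compound 1 `O=C(CCCCC(S)CCS)Nc1ccc(OC(F)(F)F)cc1` gives 19.1%
- compound 2 `Cc1cccc(NC(=O)CCCCC(S)CCS)c1` gives 9.43%
- compound 3 `O=C(CCCCC(CCSC(=O)c1ccccc1)SC(=O)c1ccccc1)Nc1ccccc1` gives 5.93%

In this assay, compound 3 lies within the scatter of compound 2 and beyond the scatter under compound 1. Compound 4 `O=C(CCCCC(CCSC(=O)c1ccccc1)SC(=O)c1ccccc1)Nc1ccc(Cl)cc1` differs from compound 3 by one change, chloro in place of hydrogen on an aromatic carbon, para to a large group (chloro in place of hydrogen on an aromatic carbon). For the measured compounds named here, no two measured compounds differ in one place only, so the data hold no direct precedent for this change. The estimated step of a number 3.1 percentage points higher from compound 3 to compound 4 (within the scatter) is therefore expected to be small and to stay within the scatter, with no firm direction. Compound 4 is estimated at 9% (expected range 3% to 20%).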

Compound 4, percent growth inhibition at one concentration: 9.8%
Estimate against measurement, compound 4: 0.8 percentage points below, within the range that was stated.
By their numbers in this assay, from the lowest: compounds 3, 2, 4 and 1 (each within the scatter of the next, the first and the last beyond it).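

In this assay, for the compounds shown here, the pair gives the first reading of one change alone: chloro in place of hydrogen on an aromatic carbon, para to a large group, gives a number 3.9 percentage points higher from compound 3 to compound 4 (within the scatter). At this position, then, the chloro brings no difference in growth inhibition that can be told from the scatter. No measurement given bears on this result. Going by these compounds, whether an amine or a carboxylic acid at the same position would move the number beyond the scatter remains open. So does the effect of the same chloro on a compound with free thiol groups in place of the benzoyl thioesters.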